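Swapping the aryl on the pyridazinone nitrogen across a fluoro core

A few compounds are considered here, and "the series" means these few. Any claim that something is new, unique, unknown or untested is made for them only; others in the source may bear on it.

Measured compounds:
- compound 1, `O=C(Nc1ccc(Oc2ccnc3[nH]ccc23)cc1)c1nn(-c2ccc(Br)cc2F)ccc1=O`: 46400 nM
- compound 2, `O=C(Nc1ccc(Oc2ccnc3[nH]ccc23)cc1)c1nn(-c2ccc(Cl)c(F)c2)ccc1=O`: 5240 nM
- compound 3, `O=C(Nc1ccc(Oc2ccnc3[nH]ccc23)c(F)c1)c1nn(-c2ccc(Br)cc2F)ccc1=O`: 56500 nM

Of the compounds shown here, three have been measured in a functional assay on HepG2 cells (Homo sapiens) for cytotoxicity, read by MTT assay, with a stated time of 72 h (on this read-out higher numbers stand for weaker inhibition and lower numbers for stronger inhibition), and a fourth, compound 4 `O=C(Nc1ccc(Oc2ccnc3[nH]ccc23)c(F)c1)c1nn(-c2ccc(Cl)c(F)c2)ccc1=O`, has not.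

Compound 1 and compound 3 share almost everything; their cores differ by fluoro in place of hydrogen on an aromatic carbon. In this assay compound 1 gives 46400 nM and compound 3 gives 56500 nM, and the step of a 1.2-fold higher number from compound 1 to compound 3 (0.09 log units; within the scatter) lies within the scatter, so the two are not distinguished here.

The change that has been measured once is 4-chloro-3-fluorophenyl in place of 4-bromo-2-fluorophenyl on an aromatic nitrogen. In this assay compound 2 gives 5240 nM, and the step of an 8.9-fold lower number from compound 1 to compound 2 (0.95 log units; beyond the scatter) goes well beyond the scatter.

The change from compound 3 to compound 4 is 4-chloro-3-fluorophenyl in place of 4-bromo-2-fluorophenyl on an aromatic nitrogen. The two place descriptions are the same word for word, so this is the same change as from compound 1 to compound 2, made on a core that carries the extra fluoro.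

Compound 4 is therefore expected to sit lower than compound 3 by a step of about an 8.7-fold lower number from compound 3 to compound 4 (0.94 log units; beyond the scatter), because the same change gave an 8.9-fold lower number from compound 1 to compound 2 (0.95 log units; beyond the scatter) and because the cores of compound 1 and compound 3 differ only by a 1.2-fold higher number from compound 1 to compound 3 (0.09 log units; within the scatter). With one example of this change, the expectation is uncertain. Compound 4 is estimated at 6500 nM, within a range from 2500 nM to 20000 nM.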

Compound 4, half-maximal inhibitory concentration: 9610 nM
Estimate against measurement, compound 4: 1.5-fold (0.17 log units) below; low and high end bracket the measured number.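

In this assay, 4-chloro-3-fluorophenyl in place of 4-bromo-2-fluorophenyl on the aromatic nitrogen again gives a clear step on the core with the extra fluoro, a 5.9-fold lower number from compound 3 to compound 4 (0.77 log units; beyond the scatter), and the size of that step does not differ from the earlier one: the same change on two cores in this assay, an 8.9-fold lower number (0.95 log units; beyond the scatter) from compound 1 to compound 2 and a 5.9-fold lower number (0.77 log units; beyond the scatter) from compound 3 to compound 4, 1.5-fold (0.18 log units) apart, within the scatter of two such steps
The extra fluoro on the core remains a small change with either aryl group, a 1.8-fold higher number from compound 2 to compound 4 (0.26 log units; within the scatter), and this too agrees with the earlier step: the same change on two cores in this assay, a 1.2-fold higher number (0.09 log units; within the scatter) from compound 1 to compound 3 and a 1.8-fold higher number (0.26 log units; within the scatter) from compound 2 to compound 4, 1.5-fold (0.18 log units) apart, within the scatter of two such steps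
Together these show that the aryl change carries over between these two closely related cores, but they do not show that it would carry over to a core that differs more, and this one pair of aryl groups cannot separate the change of halogen from the shift of the ring fluoro.

The compounds shown leave open whether chloro alone or the new place of the fluoro accounts for the step, and how an aryl group bearing a methoxy, a nitrile or an amine would read on the same aromatic nitrogen. They also leave open whether the step would hold on a core bearing chloro or methyl in place of the extra fluoro.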